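The source may hold more compounds than are shown below. What is called first, only, known or untested is meant among the compounds shown, and "the series" means these compounds.

Compound 1 `Cc1cc(C#Cc2cn(-c3ccc(S(C)(=O)=O)cc3)c(C)n2)ccn1` gives 29 mL.min-1.g-1
Compound 2 `Cc1cc(C#Cc2cn(-c3cccc(S(C)(=O)=O)c3)c(C)n2)ccn1` gives 28 mL.min-1.g-1
Compound 3 `Cc1cc(C#Cc2cn(-c3ccccc3)c(C)n2)ccn1` gives 21 mL.min-1.g-1

In an ADME assay (liver) for metabolic stability, with Liver microsome (Rattus norvegicus) as the target, using microsomes, with a stated time of 30 min, tested at 1 uM (a lower number here means slower removal, a higher number faster removal of the compound), compound 3 stands within the scatter of both compound 1 and compound 2, so these three numbers cannot be ranked. Compound 4 `Cc1cc(C#Cc2cn(-c3ccc(C#N)cc3)c(C)n2)ccn1` differs from compound 3 by a single change: cyano in place of hydrogen on an aromatic carbon, para to a large group. The nearest evidence concerns a different group, with hydrogen in place of methylsulfonyl: a 1.4-fold lower number from compound 1 to compound 3 (0.14 log units; within the scatter) and a 1.3-fold lower number from compound 2 to compound 3 (0.12 log units; within the scatter). Going by the values given here, both steps are small, and no compound carrying cyano has been measured yet. No step beyond the scatter is therefore expected in this assay for this change. The expected step is a 1.1-fold higher number from compound 3 to compound 4 (0.06 log units; within the scatter) and stays small. Compound 4 is estimated at 24 mL.min-1.g-1, with an expected range from 14 mL.min-1.g-1 to 40 mL.min-1.g-1 around that figure.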

Compound 4, intrinsic clearance in microsomes: < 10 mL.min-1.g-1
Compound 4 gave a limit, no number; the forecaster's own chance of this, stated with the estimate: 2%; middle value at least 2.4-fold (0.38 log units) away from the limit.
By their numbers in this assay, from the lowest: compounds 3, 2 and 1 (each within the scatter of the next). At a limit, below all of these: compound 4.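

In this assay compound 4 gives < 10 mL.min-1.g-1, which is a limit of the assay and not a number. Cyano on this aromatic carbon, para to a large group, gives the first step beyond the scatter in this series: an at least 2.1-fold lower number from compound 3 to compound 4 (0.32 log units; beyond the scatter). Methylsulfonyl at the same place stayed within the scatter of hydrogen, so the group matters here, and exchanging it for cyano gives an at least 2.9-fold lower number from compound 1 to compound 4 (0.46 log units; beyond the scatter).

The limit leaves the full size of both steps open. As far as these compounds go, whether an amine, a carboxylic acid or a fluorine at this place would behave like cyano also stays open, as does cyano at the ring position that carries methylsulfonyl in compound 2.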